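Para-substituent swap on the benzylhydrazine arm: methoxy to tert-butyl

This account rests on a few compounds, and the source may have more. Where it says the series, first, only, none or still open, it means among the compounds named here.

Compound 2 `COc1ccc(CNN2CCN(c3nc(=O)c4cc(C(F)(F)F)cc([N+](=O)[O-])c4s3)CC2)cc1` carries a methoxy group on the benzyl ring of the shared core. In an ADME assay on Vero cells (Chlorocebus sabaeus) for cytotoxicity, read by MTT assay, with a stated time of 72 h (a higher number here means that more compound is tolerated, a lower number that less compound is tolerated), compound 2 gives > 64 ug/mL, which is a limit of the assay rather than a number. Among the measured compounds shown here, its only measured neighbour, compound 1 `O=c1nc(N2CCN(NCc3ccc(Cl)cc3)CC2)sc2c([N+](=O)[O-])cc(C(F)(F)F)cc12`, differs by chloro in place of methoxy on an aromatic carbon; in this assay compound 1 gives > 64 ug/mL, again a limit. For the measured compounds named here, the step that the two limits leave unreadable from compound 1 to compound 2 is therefore unreadable, and the only evidence on the measured series is the limit of > 64 ug/mL in this assay, at which 2 of the 2 values shown sit.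

Compound 3 `CC(C)(C)c1ccc(CNN2CCN(c3nc(=O)c4cc(C(F)(F)F)cc([N+](=O)[O-])c4s3)CC2)cc1` is the next member: tert-butyl in place of methoxy on an aromatic carbon. Going by the values given here, no measured step bears directly on a tert-butyl entering at this position, so the only guide is that both measured compounds sit at the limit. The expectation is that the step that the limit leaves unreadable from compound 2 to compound 3 stays within the scatter, with no direction supported by the data. Compound 3 is accordingly estimated at 70 ug/mL in this assay, with a range from 30 ug/mL to 150 ug/mL, and most likely reported again only as a limit.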

Compound 3, half-maximal cytotoxic concentration: > 64 ug/mL
Compound 3: no number, only a limit (the forecaster's own chance of this, stated with the estimate: 70%); the middle value lies beyond the limit too.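

In this assay compound 3 gives > 64 ug/mL, again a limit and not a number, so its steps from compound 1 and compound 2 cannot be read. The compounds shown leave open whether chloro, methoxy and tert-butyl on the benzyl ring differ at all in this assay: the limit of > 64 ug/mL in this assay, at which 3 of the 3 values shown sit.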